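This account rests on a few compounds, and the source may have more. Where it says the series, first, only, none or still open, it means among the compounds named here.

Measured so far:
compound 1 `CN1CCCN(C(=O)CCCOc2cc(C(=O)N3CCCCc4sccc43)ccc2NC(=O)c2ccccc2-c2ccccc2)CC1` — in a functional assay on the whole organism for antagonist activity, with Rattus norvegicus as the target (on this read-out higher numbers stand for an effect only at larger amounts of compound and lower numbers for an effect already at smaller amounts), compound 1 gives 0.008 mg/kg
compound 2 `O=C(Nc1ccc(C(=O)N2CCCCc3sccc32)cc1O)c1ccccc1-c1ccccc1` — in this assay compound 2 gives 0.04 mg/kg

Compound 2 stands at the higher of the two numbers in this assay; compound 1 is lower by a margin beyond the usual scatter. Among the compounds with values here, the two differ in more than one place, so no single step joins them. Compound 3 `CN1CCN(C(=O)CCCOc2cc(C(=O)N3CCCCc4sccc43)ccc2NC(=O)c2ccccc2-c2ccccc2)CC1` differs from compound 2 by 3-((4-methylpiperazin-1-yl)carbonyl)propyl in place of hydrogen on an oxygen on an aromatic ring. Compound 1 carries a related chain at the same oxygen and gives 0.008 mg/kg, so a downward step beyond the scatter is expected, a 4.0-fold lower number from compound 2 to compound 3 (0.60 log units; beyond the scatter). Compound 3 is therefore expected to give about 0.01 mg/kg, within 0.004 mg/kg to 0.03 mg/kg.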

Compound 3, dose for 50% inhibition: 0.03 mg/kg
Compound 3: middle estimate off by 3.0-fold (0.48 log units), on the low side; the measured number falls inside the stated range.
By their numbers in this assay, from the lowest: compound 1; then compounds 3 and 2 (each within the scatter of the next).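

In this assay the 3-((4-methylpiperazin-1-yl)carbonyl)propyl group in place of hydrogen on this oxygen gives no change beyond the scatter (a 1.3-fold lower number from compound 2 to compound 3 (0.12 log units; within the scatter)), so this chain can be carried here without a clear shift in the number. At the end of the chain, 4-methylpiperazin-1-yl in place of 4-methyl-1,4-diazepan-1-yl does separate the two compounds (a 3.8-fold higher number from compound 1 to compound 3 (0.57 log units; beyond the scatter)), so the ring on the carbonyl carbon matters in this series. No measurement at hand accounts for that difference. Open, going by these compounds, is how a carboxylic acid, a simple dimethylamine or a longer chain at this oxygen would read out.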